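A methylamino group takes the place of bromine

A few compounds are considered here, and "the series" means these few. Any claim that something is new, unique, unknown or untested is made for them only; others in the source may bear on it.

Three compounds have been measured in a functional assay on LoVo cells (Homo sapiens) for cytotoxicity, read by MTT assay, with a stated time of 72 h; on this read-out lower numbers stand for stronger inhibition and higher numbers for weaker inhibition:

Compound 1, `O=C(Nc1ccc(-n2ncc3c(C(F)(F)F)cccc32)cc1)Nc1ccc(Cl)c(C(F)(F)F)c1`: 3000 nM
Compound 2, `O=C(Nc1ccc(-n2ncc3c(Br)cccc32)cc1)Nc1ccc(Cl)c(C(F)(F)F)c1`: 1700 nM
Compound 3, `O=C(Nc1ccc(-n2ncc3ccccc32)cc1)Nc1ccc(Cl)c(C(F)(F)F)c1`: 8700 nM

All three share one core and differ only in a single group on the fused ring. Compound 2 has the lowest number of the three: one step is a 1.8-fold lower number from compound 1 to compound 2 (0.25 log units; within the scatter), which stays within the scatter, while the other is a 5.1-fold higher number from compound 2 to compound 3 (0.71 log units; beyond the scatter), which lies beyond it. Compound 1 against compound 3 gives a 2.9-fold higher number from compound 1 to compound 3 (0.46 log units; beyond the scatter).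

Compound 4, `CNc1cccc2c1cnn2-c1ccc(NC(=O)Nc2ccc(Cl)c(C(F)(F)F)c2)cc1`, is the next step from compound 2. The change is methylamino in place of bromo on an aromatic carbon. Within the data shown here, two measured steps bear on this position: removing bromo entirely (compound 2 to compound 3) raised the number clearly, and exchanging bromo for trifluoromethyl (compound 1 to compound 2) moved it only within the scatter. Going by these compounds, a group is therefore not without effect here, but methylamino resembles neither of the groups tried, and its direction is unknown. The estimate for compound 4 in this assay is 4000 nM, between 1000 nM and 16000 nM, a step of a 2.4-fold higher number from compound 2 to compound 4 (0.37 log units; beyond the scatter), expected to be a modest rise.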

Compound 4, half-maximal inhibitory concentration: 6300 nM
For compound 4 the middle estimate is 1.6-fold (0.20 log units) below the measured one, within the range that was stated.
By their numbers in this assay, from the lowest: compounds 2 and 1 (each within the scatter of the next); then compounds 4 and 3 (each within the scatter of the next).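

In this assay, methylamino does not keep the lower number seen with bromo: the change gives a 3.7-fold higher number from compound 2 to compound 4 (0.57 log units; beyond the scatter), a modest step, and trifluoromethyl also stands apart from methylamino, with a 2.1-fold higher number from compound 1 to compound 4 (0.32 log units; beyond the scatter). Against the compound with only hydrogen at this position, the result is a 1.4-fold lower number from compound 3 to compound 4 (0.14 log units; within the scatter), which stays within the scatter, so in this assay methylamino cannot be told apart from hydrogen, and the earlier gain over hydrogen is now seen not to extend to every group placed here. Nothing available on these compounds explains why methylamino behaves differently from bromo and trifluoromethyl.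

The compounds shown leave open whether the result belongs to nitrogen attached at this carbon in general or to methylamino in particular, a question that a plain amine, dimethylamino or an acetamide could help to answer. They also leave open how far the lower numbers extend among halogens and small carbon groups, such as chloro, fluoro, methyl or a nitrile.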